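This account rests on a few compounds, and the source may have more. Where it says the series, first, only, none or still open, it means among the compounds named here.

Compound 1 `Oc1cccc(-c2cc(-c3cccc(F)c3)cc(-c3ccccc3O)n2)c1` in a functional assay on DU-145 cells (Homo sapiens) for inhibition (on this read-out higher numbers stand for weaker inhibition and lower numbers for stronger inhibition), gives > 50000 nM, a limit of the assay rather than a number. Compound 2 `Oc1ccccc1-c1cc(-c2ccc(C(F)(F)F)cc2)cc(-c2ccccc2O)n1` gives > 50000 nM, likewise only a limit.

Compound 2 therefore stands at the limit of > 50000 nM in this assay, at which 2 of the 2 values shown sit, with no measured number of its own. Compound 3 `Oc1cccc(-c2cc(-c3ccc(C(F)(F)F)cc3)cc(-c3ccccc3O)n2)c1` is the not yet measured analogue; the change from compound 2 is 3-hydroxyphenyl in place of 2-hydroxyphenyl on an aromatic carbon. Among the measured compounds shown here, no step between two measured compounds is available, so the expected step is none beyond the scatter: compound 3 is expected to stay at the same limit, and the step that the limit leaves unreadable from compound 2 to compound 3 is taken as flat. The estimate for compound 3 is 70000 nM, within a range from 30000 nM to 200000 nM.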

Compound 3, half-maximal inhibitory concentration: > 50000 nM
Compound 3: no number, only a limit (the forecaster's own chance of this, stated with the estimate: 85%); the middle value does not contradict the limit.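

The steps from compound 1 and from compound 2 to compound 3 cannot be read, since all three compounds sit at one limit of the assay: the limit of > 50000 nM in this assay, at which 3 of the 3 values shown sit.

On these data alone, how strongly each of the three inhibits, and whether moving the hydroxyl on the hydroxyphenyl group matters at all, stays open.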